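The source may report more compounds than this note shows. Statements on the series, on what has been measured and on what is new or still open speak of the compounds shown alone.

Of the compounds shown here, three that share one core have been measured in an ADME assay on the whole organism for cytotoxicity, with Artemia salina as the target, with a stated time of 24 h; on this read-out lower numbers stand for an effect already at smaller amounts and higher numbers for an effect only at larger amounts of compound. Compound 1 `Cc1ccc(S(=O)(=O)NC(=O)Nc2ccccc2C(=O)/C=C/c2ccccc2O)cc1` gives 32.3 ug/mL. Compound 2 `CCOc1cc(/C=C/C(=O)c2ccccc2NC(=O)NS(=O)(=O)c2ccc(C)cc2)ccc1O` gives 19.2 ug/mL. Compound 3 `Cc1ccc(S(=O)(=O)NC(=O)Nc2ccccc2C(=O)/C=C/c2cc(O)ccc2[N+](=O)[O-])cc1` gives 18.3 ug/mL. Among these three numbers compound 2 stands second highest: its nearest neighbour is compound 3, with a 1.0-fold lower number from compound 2 to compound 3 (0.02 log units; within the scatter), and its furthest is compound 1, with a 1.7-fold lower number from compound 1 to compound 2 (0.23 log units; within the scatter). Compound 4 `Cc1ccc(S(=O)(=O)NC(=O)Nc2ccccc2C(=O)/C=C/c2ccc[nH]2)cc1` is not yet measured. It differs from compound 2 by 1H-pyrrol-2-yl in place of 3-ethoxy-4-hydroxyphenyl on a double-bonded chain carbon bound to a double-bonded chain carbon. Among the compounds with values here, three measured steps bear on this place, a double-bonded chain carbon bound to a double-bonded chain carbon: the two named already and a 1.8-fold lower number from compound 1 to compound 3 (0.25 log units; within the scatter); none of them reaches beyond the scatter. Within the data shown here, all three, however, swap one six-membered aromatic ring of carbon only for another, whereas compound 4 brings in a five-membered aromatic ring with one hetero atom, which no measured compound carries, so there is no direct precedent for it. On the evidence of the three measured steps, the step of a 1.1-fold higher number from compound 2 to compound 4 (0.04 log units; within the scatter) is expected to remain within the scatter. Compound 4 is therefore estimated at 21 ug/mL, with a range from 9 ug/mL to 48 ug/mL.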

Compound 4, concentration for half-maximal effect: 32.1 ug/mL
Compound 4: the middle estimate sits 1.5-fold (0.18 log units) below what was measured; the range from low to high includes it.
By their numbers in this assay, from the lowest: compounds 3, 2, 4 and 1 (each within the scatter of the next).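

In this assay, the 1H-pyrrol-2-yl of compound 4, the only five-membered aromatic ring with one hetero atom in this set, stays within the scatter of all three six-membered aromatic rings of carbon only (a 1.7-fold higher number from compound 2 to compound 4 (0.22 log units; within the scatter)) (a 1.8-fold higher number from compound 3 to compound 4 (0.24 log units; within the scatter)) (a 1.0-fold lower number from compound 1 to compound 4 (0.00 log units; within the scatter)). On a double-bonded chain carbon bound to a double-bonded chain carbon, this read-out therefore separates neither the two ring types nor, in the change from compound 2 to compound 4, 3-ethoxy-4-hydroxyphenyl with its hydrogen-bond acceptors from 1H-pyrrol-2-yl with none. Nothing measured here offers an explanation for these values.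

The compounds shown leave open whether this place would stay within the scatter once it carries something other than an aromatic ring, such as a longer chain, an amine or a carboxylic acid. They also leave open whether the same holds for changes elsewhere on the shared core, since every step shown falls at this one place.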